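The compounds below may be only part of what the source reports. "The series", "measured", "known", "first", "only" and "open" are said of these compounds alone.

In a functional assay on HT-29 cells (Homo sapiens) for inhibition, with a stated time of 72 h (on this read-out lower numbers stand for stronger inhibition and higher numbers for weaker inhibition), compound 1 (`COc1cc(C(=O)c2ccc3[nH]ccc3c2)cc(OC)c1OC`) gives 100 nM while compound 2 (`COc1cc(C(=O)c2ccc3cc[nH]c3c2)cc(OC)c1OC`) gives 330 nM and compound 3 (`COc1cc(C(=O)c2cccc3cc[nH]c23)cc(OC)c1OC`) gives 250 nM as its reading. Compound 1 therefore has the lowest number of the three, with both gaps beyond the usual scatter. Compound 4 (`COc1cc(C(=O)c2ccc3c(ccn3CC(=O)O)c2)cc(OC)c1OC`) keeps the core of compound 1 but carries carboxymethyl in place of hydrogen on an aromatic nitrogen. Among the measured compounds shown here, no measured pair shows a change at that place, so any forecast here is a judgement. A large step towards weaker inhibition in this assay is expected, with the estimated change (a 15-fold higher number from compound 1 to compound 4 (1.18 log units; beyond the scatter)) well beyond the scatter. Compound 4 is estimated at 1500 nM within an expected range from 300 nM to 8000 nM for this measurement.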

Compound 4, half-maximal inhibitory concentration: 460 nM
The estimate for compound 4 lay 3.3-fold (0.51 log units) above the measured number; low and high end bracket the measured number.
By their numbers in this assay, from the lowest: compound 1; then compounds 3, 2 and 4 (each within the scatter of the next).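

In this assay, placing carboxymethyl in place of hydrogen on the aromatic nitrogen gives a 4.6-fold higher number from compound 1 to compound 4 (0.66 log units; beyond the scatter), a modest loss. The earlier compounds shown here left this nitrogen untouched; now compound 4 shows that it can carry a substituent while inhibition remains measurable at 460 nM. Nothing available explains why inhibition weakens at this position. On these data alone, it remains open whether the loss follows from the carboxylic acid or simply from having any group there. A methyl group or a longer chain ending in an amine, on the same nitrogen, could help to tell these apart.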